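The source may hold more compounds than are shown below. What is called first, only, known or untested is meant among the compounds shown, and "the series" means these compounds.

Three compounds built on one shared core were measured in an assay on HEK293 cells for inhibition of Steryl-sulfatase (Homo sapiens), tested at 1 uM; a higher number here means a stronger effect of the compound at the concentration tested, a lower number a weaker effect. Compound 1 `CCN(Cc1cccc(Br)c1)c1ccc(C(=O)N2CCc3ccc(OS(N)(=O)=O)cc3C2)cc1` gives 97.2%, compound 2 `NS(=O)(=O)Oc1ccc2c(c1)CN(C(=O)c1cccc(N3CCN(c4ncccn4)CC3)c1)CC2` gives 24.4%, and compound 3 `CCCN(CCC)c1cccc(C(=O)N2CCc3ccc(OS(N)(=O)=O)cc3C2)c1` gives 54.8%. Compound 3 thus stands second highest of the three, beyond the scatter below compound 1 and beyond the scatter above compound 2.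

Compound 4 `CCN(Cc1ccccc1)c1cccc(C(=O)N2CCc3ccc(OS(N)(=O)=O)cc3C2)c1` has not yet been measured. It differs from compound 3 in one place: benzyl(ethyl)amino in place of dipropylamino on an aromatic carbon. Going by the values given here, no step between two measured compounds isolates this change, so the outlook rests on the values themselves. Compound 1, which also carries a benzyl(ethyl)amino group, gives 97.2% in this assay. A rise beyond the scatter is expected, a number 25.2 percentage points higher from compound 3 to compound 4 (beyond the scatter). Compound 4 is estimated to give 80%, with a range from 55% to 95%.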

Compound 4, a percentage reported as inhibition, at one concentration (the size of the read-out at that concentration, not a potency): 69%
Estimate against measurement, compound 4: 11 percentage points above; measured number inside the range.
By their numbers in this assay, from the lowest: compound 2; then compound 3; then compound 4; then compound 1.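

In this assay, benzyl(ethyl)amino in place of dipropylamino gives a number 14.2 percentage points higher from compound 3 to compound 4 (beyond the scatter) at this position, meta to a large group. Going by these compounds alone, this is the first single-place change, and it shows that this position accepts a six-membered aromatic ring of carbon only in the amino group, with a modest gain beyond the scatter. No measured evidence accounts for this rise. The compounds shown leave open whether a longer chain such as dibutylamino would hold or lose this effect on the same aromatic carbon. They also leave open what a carboxylic acid on the benzyl group would do.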